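This account rests on a few compounds, and the source may have more. Where it says the series, first, only, none or still open, it means among the compounds named here.

Two compounds share one core and differ only in the group on the amide-type nitrogen. Compound 1 `Cc1ccccc1NC(=O)CCC(=O)OCCCCCCSc1ccc([N+](=O)[O-])c2nonc12` gives 1410 nM in an ADME assay on HUVEC cells (Homo sapiens) for cytotoxicity, read by MTT assay, with a stated time of 72 h; on this read-out higher numbers stand for weaker inhibition and lower numbers for stronger inhibition. Compound 2 `O=C(CCC(=O)OCCCCCCSc1ccc([N+](=O)[O-])c2nonc12)Nc1ccc(C(F)(F)F)cc1` gives 1390 nM in this assay. Among the measured compounds shown here, the one step measured so far, a 1.0-fold lower number from compound 1 to compound 2 (0.01 log units; within the scatter), exchanges one aromatic ring for another and lies within the scatter. On the numbers shown, compound 2 holds the lowest of the two, and its nearest neighbour, compound 1, sits within the scatter of it. Compound 3 `O=C(CCC(=O)OCCCCCCSc1ccc([N+](=O)[O-])c2nonc12)NCCN1CCCC1` has not yet been measured. It differs from compound 2 in one place: 2-(pyrrolidin-1-yl)ethyl in place of 4-(trifluoromethyl)phenyl on an amide-type nitrogen. Here a six-membered aromatic ring of carbon only leaves and a five-membered non-aromatic ring with 1 hetero atom enters, a different kind of change from the measured step, which is therefore only a weak guide. With no stronger guide, compound 3 is expected to land close to compound 2, a 1.1-fold higher number from compound 2 to compound 3 (0.03 log units; within the scatter), with a wide range. Compound 3 is estimated at 1500 nM, between 500 nM and 5000 nM.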

Compound 3, half-maximal inhibitory concentration: 6070 nM
The estimate for compound 3 lay 4.0-fold (0.61 log units) below the measured number; measured number above the stated range.
By their numbers in this assay, from the lowest: compounds 2 and 1 (each within the scatter of the next); then compound 3.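

In this assay the two aromatic groups gave numbers within the scatter of each other, so the group on this amide-type nitrogen could have seemed to matter little. Compound 3 shows otherwise, with a 4.4-fold higher number from compound 2 to compound 3 (0.64 log units; beyond the scatter) and a 4.3-fold higher number from compound 1 to compound 3 (0.63 log units; beyond the scatter) when 2-(pyrrolidin-1-yl)ethyl takes the place of either aromatic group, a modest move toward weaker inhibition. Nothing available here explains this move.

The compounds shown leave open which part of the new group goes with the higher number, the non-aromatic ring with its nitrogen or the ethyl chain that carries it. A morpholine ring or a dimethylamino group on the same ethyl chain, or a plain hexyl chain on this nitrogen, could help separate these parts.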